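Methoxy for Nitro in a Series at Its Limit

A few compounds are considered here, and "the series" means these few. Any claim that something is new, unique, unknown or untested is made for them only; others in the source may bear on it.

In a functional assay on A549 cells (Homo sapiens) for cytotoxicity, read by MTT assay, with a stated time of 72 h (on this read-out lower numbers stand for stronger inhibition and higher numbers for weaker inhibition), compound 1 `CNC(=O)c1cc(Oc2ccc(NC(=O)c3cc(-c4ccc(Br)cc4)ncn3)cc2)ccn1` gives > 100000 nM, which is a limit of the assay and not a number. Compound 2 `CNC(=O)c1cc(Oc2ccc(NC(=O)c3nccc(-c4ccc([N+](=O)[O-])cc4)n3)cc2)ccn1` gives > 100000 nM, and this too is only a limit. Compound 3 `CNC(=O)c1cc(Oc2ccc(NC(=O)c3nccc(-c4ccc(OC)cc4)n3)cc2)ccn1` departs from compound 2 by one change, methoxy in place of nitro on an aromatic carbon. Within the data shown here, no measured step yet shows what such a change does in this assay. The expected change, an at least 1.2-fold lower number from compound 2 to compound 3 (0.09 log units; that floor lies within the scatter), is small and towards stronger inhibition, and the reading may again be only a limit. Compound 3 is expected at 80000 nM, with an estimated range of 20000 nM to 200000 nM.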

Compound 3, half-maximal inhibitory concentration: 11100 nM
The estimate for compound 3 lay 7.2-fold (0.86 log units) above the measured number, outside the stated range (below it).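

In this assay, methoxy in place of nitro on this aromatic carbon gives an at least 9.0-fold lower number from compound 2 to compound 3 (0.95 log units; beyond the scatter), so this position can move the read-out off its limit. Compound 3 is the first compound shown with a number, and the full size of the step stays unknown because the reading for compound 2 is only a limit: the limit of > 100000 nM in this assay, at which 2 of the 3 values shown sit.

Compound 1 differs from compound 3 in more than one place and cannot be compared with it. Going by these compounds, whether methoxy itself matters stays open, and a hydroxyl, an amine or a longer ether chain at this position would test that.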